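A cyano group added to the benzyl ether of compound 3

A few compounds are considered here, and "the series" means these few. Any claim that something is new, unique, unknown or untested is made for them only; others in the source may bear on it.

The series is followed in a functional assay on KBVIN cells (Homo sapiens) for antiproliferative activity, read by sulforhodamine B assay, with a stated time of 72 h (on this read-out lower numbers stand for stronger inhibition of growth and higher numbers for weaker inhibition of growth), where compound 1 `Cc1cc(=O)oc2cc(Sc3cccc(Cl)n3)ccc12` gives 920 nM. Compound 2 `CCc1cc(=O)c2ccc(Sc3cccc(Cl)n3)c(C)c2o1` gives 23900 nM in this assay, and compound 3 `CCc1cc(=O)c2ccc(OCc3ccccc3)c(C)c2o1` gives 24800 nM. Compound 3 thus carries the highest number of the three; the value of compound 2 lies within the scatter of it, so the two cannot be set in order, while the value of compound 1 lies beyond the scatter and is clearly lower. For the measured compounds named here, no pair of measured compounds differs in only one place, so no step between measured compounds is available to guide the next change.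

Compound 4 `CCc1cc(=O)c2ccc(OCc3cccc(C#N)c3)c(C)c2o1` differs from compound 3 by cyano in place of hydrogen on an aromatic carbon. Going by the values given here, nothing among the measured compounds shows what a cyano group on this benzyl ring does. The step of a 1.2-fold lower number from compound 3 to compound 4 (0.09 log units; within the scatter) is therefore expected to stay within the scatter, with no clear direction. Compound 4 is estimated at 20000 nM, with a range from 6000 nM to 60000 nM in this assay.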

Compound 4, concentration for 50% growth inhibition: > 31300 nM
Compound 4: a limit, no number; the forecaster's own chance of this, stated with the estimate: 15%; middle value at least 1.5-fold (0.19 log units) from the limit.
By their numbers in this assay, from the lowest: compound 1; then compounds 2 and 3 (each within the scatter of the next). At a limit, above all of these: compound 4.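

In this assay compound 4 gives > 31300 nM, which is a limit of the assay and not a number. For the compounds shown here, this is the first step between compounds that differ in one place, and it reads as an at least 1.2-fold higher number from compound 3 to compound 4 (0.10 log units; that floor lies within the scatter). It shows that going from phenyl to 3-cyanophenyl on the benzyl ether brings no visible gain in growth inhibition, while how far compound 4 truly lies from compound 3 cannot be read: the limit of > 31300 nM in this assay, at which 1 of the 4 values shown sits.

From the compounds shown here alone, whether an amine, a carboxylic acid or a methoxy group at this place, or cyano elsewhere on the same ring, would give a lower number stays open. Also open, going by these compounds, is what sets compound 1 apart from the others, since no single change links it to any of them.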